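Piperidine substituent exchange in the TRPV1 antagonist series

The source may hold more compounds than are shown below. What is called first, only, known or untested is meant among the compounds shown, and "the series" means these compounds.

Measured compounds:
compound 1 `CC(C(=O)NCc1ccc(C(F)(F)F)nc1N1CCCC1)c1ccc(NS(C)(=O)=O)c(F)c1` with 211 nM
compound 2 `CCCCOC1CCN(c2nc(C(F)(F)F)ccc2CNC(=O)C(C)c2ccc(NS(C)(=O)=O)c(F)c2)CC1` with 28.2 nM

For the measured compounds named here, in a functional assay on CHO-K1 cells for antagonist activity at transient receptor potential cation channel subfamily V member 1 (Homo sapiens), read by FLIPR (a lower number here means a stronger inhibitor, a higher number a weaker inhibitor), compound 2 gives the lowest number of the two; compound 1 stands a 7.5-fold lower number from compound 1 to compound 2 (0.87 log units; beyond the scatter) away from it, the only step recorded in this assay. Compound 3 `CC(C(=O)NCc1ccc(C(F)(F)F)nc1N1CCC(CN(C)C)CC1)c1ccc(NS(C)(=O)=O)c(F)c1` is not yet measured. It differs from compound 2 by (dimethylamino)methyl in place of butoxy on a saturated ring carbon. Going by the values given here, the one measured step, from compound 1 to compound 2, concerns the ring itself and carries the butoxy group in; no measured pair isolates the group on the saturated ring carbon, so nothing shows how the (dimethylamino)methyl group compares with butoxy. The expectation for compound 3 is therefore anchored on compound 2 with wide bounds, the step of a 2.1-fold higher number from compound 2 to compound 3 (0.33 log units; beyond the scatter) being taken as small and uncertain in direction. Compound 3 is estimated at 60 nM, within 15 nM to 250 nM.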

Compound 3, half-maximal inhibitory concentration: 426 nM
Compound 3: the middle estimate sits 7.1-fold (0.85 log units) below what was measured; the measured number lies above the stated range.
By their numbers in this assay, from the lowest: compound 2; then compound 1; then compound 3.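

In this assay, the group on the saturated ring carbon, three ring bonds from the ring nitrogen, has a large effect on its own: (dimethylamino)methyl in place of butoxy gives a 15-fold higher number from compound 2 to compound 3 (1.18 log units; beyond the scatter), although neither group has a ring or a net charge. The enlarged ring therefore does not bring a gain whatever it carries, since 4-((dimethylamino)methyl)piperidin-1-yl in place of pyrrolidin-1-yl gives a 2.0-fold higher number from compound 1 to compound 3 (0.31 log units; beyond the scatter), opposite in direction to a 7.5-fold lower number from compound 1 to compound 2 (0.87 log units; beyond the scatter). No available measurement accounts for the difference between the two groups.

Still open, as far as these compounds go, is how a plain pentyl chain, a shorter ether such as methoxy, or a carboxylic acid on the same ring carbon would compare with butoxy. The unsubstituted six-membered ring is also absent, so the contribution of the ring alone cannot be separated from that of its substituent.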